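The source may report more compounds than this note shows. Statements on the series, on what has been measured and on what is new or still open speak of the compounds shown alone.

Measured so far in a functional assay on the whole organism (stomach) for inhibition, with Rattus norvegicus as the target, at a dose of 100 mg/kg by the intraduodenal route; on this read-out lower numbers stand for less inhibition and higher numbers for more inhibition at the one dose given (going by the name of the read-out):
compound 1 `N=C(S)CCCn1nc(-c2ccccc2)ccc1=O` gives 75.6%
compound 2 `N#CCCn1nc(-c2ccccc2)ccc1=O` gives 10.1%

Compound 2 stands lowest of the two numbers; compound 1 sits a number 65.5 percentage points lower from compound 1 to compound 2 (beyond the scatter) in the opposite sense. Compound 3 `C/N=C(\S)CCn1nc(-c2ccccc2)ccc1=O` differs from compound 2 by a group of 4 heavy atoms (2 carbon, 1 nitrogen, 1 sulfur; no ring) in place of a group of 2 heavy atoms (1 carbon, 1 nitrogen; no ring), on a saturated chain carbon, two bonds along the chain from an aromatic nitrogen. Going by the values given here, the one step that bears on this is a number 65.5 percentage points lower from compound 1 to compound 2 (beyond the scatter), where a cyano replaced a group of 4 heavy atoms at the same place and the number fell sharply. Reversing that exchange, with a group of 4 heavy atoms entering, a large rise in this assay is expected, so the step of a number 49.9 percentage points higher from compound 2 to compound 3 (beyond the scatter) is estimated. Compound 3 is expected to give 60%, within 30% to 85%.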

Compound 3, a percentage reported as inhibition, in the whole organism at one dose (the size of the read-out at that dose, not a potency): 68.2%
The estimate for compound 3 lay 8.2 percentage points below the measured number, within the range that was stated.
By their numbers in this assay, from the lowest: compound 2; then compounds 3 and 1 (each within the scatter of the next).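

In this assay, the step to a number a number 58.1 percentage points higher from compound 2 to compound 3 (beyond the scatter) shows that the high reading does not belong to the group of compound 1 alone: a second group of 4 heavy atoms, also holding sulfur, stands far above the cyano. The two such groups are not separated, with a number 7.4 percentage points lower from compound 1 to compound 3 (within the scatter). No measurement available here bears on what lies behind the gap to the cyano.

As far as these compounds go, whether the sulfur is needed remains open, and a primary amide at this place would address that. From the compounds shown here alone, how an amine or a carboxylic acid would read is also open.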